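Series notes: hydrogen in place of methyl

This account rests on a few compounds, and the source may have more. Where it says the series, first, only, none or still open, it means among the compounds named here.

In a functional assay on SK-BR-3 cells (Homo sapiens) for antiproliferative activity, with a stated time of 72 h (on this read-out higher numbers stand for weaker inhibition of growth and lower numbers for stronger inhibition of growth), compound 1 (`COc1ccc(CN(C)C(=O)c2cc(Cl)c(O)cc2O)cc1OC`) gives 7700 nM and compound 2 (`Cc1cccc(CN(C)C(=O)c2cc(Cl)c(O)cc2O)c1`) gives 11300 nM. For the measured compounds named here, compound 2 thus stands within the usual scatter of compound 1, the only other measured compound, and these numbers do not separate the two. Compound 3 (`CN(Cc1ccccc1)C(=O)c1cc(Cl)c(O)cc1O`) is still unmeasured. Relative to compound 2, it has hydrogen in place of methyl on an aromatic carbon. Going by the values given here, no measured pair differs in one place only, so the series gives no direct reading of this change. Taking compound 2 at 11300 nM as the starting point, no shift beyond the scatter is expected in this assay. The estimated step of a 1.1-fold lower number from compound 2 to compound 3 (0.05 log units; within the scatter) is small and has no firm direction. For compound 3 the expected value is 10000 nM, with an estimated range from 5000 nM to 20000 nM.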

Compound 3, concentration for 50% growth inhibition: 18300 nM
Estimate against measurement, compound 3: 1.8-fold (0.26 log units) below; low and high end bracket the measured number.
By their numbers in this assay, from the lowest: compounds 1, 2 and 3 (each within the scatter of the next, the first and the last beyond it).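

This gives the series its first direct reading of a single-place change: going from 3-methylphenyl to phenyl in this assay is a 1.6-fold higher number from compound 2 to compound 3 (0.21 log units; within the scatter). At this aromatic carbon, meta to a large group, the numbers therefore do not separate methyl from hydrogen, so this one methyl has no effect that can be resolved from the scatter of the read-out. No measurement shown here offers an explanation for this result.

On these data alone, it remains open whether a different group at this carbon, such as an amine, a carboxylic acid or a longer chain, would give a step beyond the scatter. The two methoxy groups of compound 1 also have no partner among these compounds that differs in one place only, so their individual contributions cannot be read.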